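This account rests on a few compounds, and the source may have more. Where it says the series, first, only, none or still open, it means among the compounds named here.

The question here is how much compound cells tolerate, as measured in an ADME assay on NIH3T3 cells (Mus musculus) for cytotoxicity, read by neutral red uptake, with a stated time of 48 h; a lower number here means that less compound is tolerated, a higher number that more compound is tolerated. Compound 1 `CCCCCCCC/C=C\c1c(C)cc(C)nc1CCCOC` has "not determined" (no result reported) as its entry in this assay and so offers no number. Going by the values given here, compound 2 `CCCCCCCC/C=C\c1c(C)c(/C=C\CCCCCCCC)c2[n+](c1C)CCC2` gives 22.7 uM as the only number available, so it cannot yet be ranked against another compound. Compound 3 `CCCCCCCC/C=C\c1c(C)cc(C)[n+]2c1CCC2` still awaits measurement. Its structure departs from that of compound 2 hydrogen in place of dec-1-en-1-yl on an aromatic carbon by having hydrogen in place of dec-1-en-1-yl on an aromatic carbon. Among the compounds with values here, no measured pair shows what such a change does, so any forecast is loose. A moderate step toward a higher number, just beyond the usual scatter, is expected, meaning more compound tolerated. The estimated change is a 2.2-fold higher number from compound 2 to compound 3 (0.34 log units; beyond the scatter) in that direction. In this assay the expected value for compound 3 is 50 uM with a range from 15 uM to 130 uM as the likely span.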

Compound 3, half-maximal toxic concentration: 1.9 uM
Compound 3: the middle estimate sits 26-fold (1.42 log units) above what was measured; measured number outside the range, below it.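

Replacing dec-1-en-1-yl with hydrogen on this aromatic carbon gives a 12-fold lower number from compound 2 to compound 3 (1.08 log units; beyond the scatter) in this assay and means that cells tolerate much less of the compound once the chain is gone. Going by these compounds alone, this is the first measured step at this position, and it shows that the group there matters greatly for this read-out, with the dec-1-en-1-yl group going along with more tolerance, not less. The data shown offer no measurement that explains why the number moves in this direction.

Going by these compounds, with only hydrogen and dec-1-en-1-yl compared here, it remains open whether a shorter butyl chain, a saturated decyl chain or an amine at this carbon would fall between compound 2 and compound 3 or outside that span. Within the data shown here, whether the same exchange would act alike on a different core also remains open, since this single pair is the only evidence.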